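The source may report more compounds than this note shows. Statements on the series, on what has been measured and on what is new or still open speak of the compounds shown alone.

Series notes. Among the compounds with values here, compound 1 `CS/C(=N\C(=O)c1ccno1)NC(=O)c1ccno1`, compound 2 `O=C(/N=C(/NC(=O)c1ccno1)[Se]Cc1ccccc1)c1ccno1` and compound 3 `O=C(/N=C(/NC(=O)c1cccs1)[Se]Cc1ccccc1)c1cccs1` are the measured members so far. In a functional assay on MCF7 cells (Homo sapiens) for cytotoxicity, read by MTT assay, with a stated time of 72 h (on this read-out higher numbers stand for weaker inhibition of growth and lower numbers for stronger inhibition of growth), compound 1 gives > 100000 nM, which is a limit of the assay and not a number. In this assay compound 2 gives > 100000 nM, again a limit. In this assay compound 3 gives > 100000 nM, also a limit. The change a group of 2 heavy atoms (1 carbon, 1 sulfur; no ring) in place of a group of 8 heavy atoms (7 carbon, 1 selenium; one six-membered aromatic ring of carbon only), on a carbon with a double bond to nitrogen gave the step that the two limits leave unreadable from compound 2 to compound 1, which stays unreadable since (the limit of > 100000 nM in this assay, at which 3 of the 3 values shown sit). The same change, (a group of 2 heavy atoms (1 carbon, 1 sulfur; no ring) in place of a group of 8 heavy atoms (7 carbon, 1 selenium; one six-membered aromatic ring of carbon only), on a carbon with a double bond to nitrogen), leads to the unmeasured compound 4 `CS/C(=N\C(=O)c1cccs1)NC(=O)c1cccs1`. How the core of compound 2 differs from the core of compound 3 is not broken down here. The step from compound 3 to compound 4 is expected to be a step that the limit leaves unreadable from compound 3 to compound 4, resting on the unreadable step that the two limits leave unreadable from compound 2 to compound 1 and on (the limit of > 100000 nM in this assay, at which 3 of the 3 values shown sit). Compound 4 is expected at 150000 nM, estimated to lie between 60000 nM and 500000 nM.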

Compound 4, concentration for total growth inhibition: 89000 nM
For compound 4 the middle estimate is 1.7-fold (0.23 log units) above the measured one; low and high end bracket the measured number.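

In this assay methylsulfanyl in place of the group of 8 heavy atoms, on a carbon with a double bond to nitrogen, gives an at least 1.1-fold lower number from compound 3 to compound 4 (0.05 log units; that floor lies within the scatter) on the core of compound 3, and that floor lies within the scatter. For compound 3 the value > 100000 nM is a limit and not a number. The step from compound 2 to compound 1 cannot be read, so carrying the change from one core to the other is neither confirmed nor refuted: the limit of > 100000 nM in this assay, at which 3 of the 4 values shown sit.

The compounds shown leave open whether an amine or a longer alkyl chain at this place would give a readable number in this assay on either core. They also leave open how large the step from compound 3 to compound 4 really is.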